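This account rests on a few compounds, and the source may have more. Where it says the series, first, only, none or still open, it means among the compounds named here.

Values in an ADME assay on MT4 cells (Homo sapiens) for inhibition; a higher number here means that more compound is tolerated, a lower number that less compound is tolerated:
- Compound 1 `Cc1cn([C@@H]2O[C@H](CO[Si](C)(C)C(C)(C)C)[C@@]3(OS(=O)(=O)C=C3N)[C@H]2O[Si](C)(C)C(C)(C)C)c(=O)n(CC(=O)O)c1=O`: > 155000 nM
- Compound 2 `Cc1cn([C@@H]2O[C@H](CO[Si](C)(C)C(C)(C)C)[C@@]3(OS(=O)(=O)C=C3N)[C@H]2O[Si](C)(C)C(C)(C)C)c(=O)n(/C=C/CO)c1=O`: 4000 nM
- Compound 3 `Cc1cn([C@@H]2O[C@H](CO[Si](C)(C)C(C)(C)C)[C@@]3(OS(=O)(=O)C=C3N)[C@H]2O[Si](C)(C)C(C)(C)C)c(=O)n(/C=C\CO)c1=O`: 36000 nM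

Compound 1 has no number, only a limit of > 155000 nM.

Compound 4 `Cc1cn([C@@H]2O[C@H](CO[Si](C)(C)C(C)(C)C)[C@@]3(OS(=O)(=O)C=C3N)[C@H]2O[Si](C)(C)C(C)(C)C)c(=O)n(CC2CO2)c1=O` differs from it as follows: oxiran-2-yl in place of carboxy on a saturated chain carbon bound to an aromatic nitrogen, with oxiran-2-yl in place of carboxy on a saturated chain carbon bound to an aromatic nitrogen.

Two measured steps also give up the carboxymethyl, though for 3-hydroxyprop-1-en-1-yl. There is an at least 38-fold lower number from compound 1 to compound 2 (1.58 log units; beyond the scatter), which is large, and an at least 4.3-fold lower number from compound 1 to compound 3 (0.63 log units; beyond the scatter), at least modest. These two outcomes themselves stand apart, with a 9.0-fold higher number from compound 2 to compound 3 (0.95 log units; beyond the scatter), and the fact that compounds 2 and 3 differ only in the configuration as drawn is the only separation between them.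

A clear fall in this assay is therefore expected, and the estimated step is an at least 7.7-fold lower number from compound 1 to compound 4 (0.88 log units; beyond the scatter). For compound 4 the expected value is 20000 nM, within an estimated range of 4000 nM to 100000 nM.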

Compound 4, half-maximal cytotoxic concentration: 56000 nM
Estimate against measurement, compound 4: 2.8-fold (0.45 log units) below; the range from low to high includes it.
By their numbers in this assay, from the lowest: compound 2; then compounds 3 and 4 (each within the scatter of the next). At a limit, above all of these: compound 1.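

In this assay, the fall does not depend on 3-hydroxyprop-1-en-1-yl, since (oxiran-2-yl)methyl in place of carboxymethyl also gives an at least 2.7-fold lower number from compound 1 to compound 4 (0.44 log units; beyond the scatter). The value of compound 1 is a limit, so this step is only a bound: the limit of > 155000 nM in this assay, at which 1 of the 4 values shown sits. The new group matches the form drawn Z, with a 1.6-fold higher number from compound 3 to compound 4 (0.19 log units; within the scatter), but not the form drawn E, with a 14-fold higher number from compound 2 to compound 4 (1.15 log units; beyond the scatter).

From the compounds shown here alone, it remains open whether the fall comes from losing the carboxy group or from what enters in its place. Going by these compounds, how an amine or a longer chain on this aromatic nitrogen would read in this assay also stays open.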